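The source may hold more compounds than are shown below. What is called first, only, known or untested is meant among the compounds shown, and "the series" means these compounds.

Compound 2 `CCCN(C[C@H]1Cc2c(cccc2N2CCNCC2)CN1)[C@H]1CCCc2cccnc21` gives 32.2 nM in a functional assay on CCRF-CEM cells for antagonist activity at C-X-C chemokine receptor type 4 (Homo sapiens), read by calcium flux, with stated times of 25 min and 90 s (on this read-out lower numbers stand for stronger inhibition and higher numbers for weaker inhibition), the higher of the two numbers measured in the series; compound 1 `CN(C[C@H]1Cc2c(cccc2N2CCN3CCC[C@H]3C2)CN1)[C@H]1CCCc2cccnc21` gives 2.92 nM, a gap beyond the scatter, though the two differ at more than one place. Compound 3 `CN(C[C@H]1Cc2c(cccc2N2CCNCC2)CN1)[C@H]1CCCc2cccnc21` is not yet measured. The change from compound 2 to compound 3 is hydrogen in place of ethyl on a saturated chain carbon bound to an amine nitrogen, propyl becoming methyl. Going by the values given here, no comparable single step has been measured, so the step from compound 2 to compound 3 is expected to be a 1.8-fold lower number from compound 2 to compound 3 (0.25 log units; within the scatter), a modest move downward. Compound 3 is estimated at 18 nM, within 6 nM to 55 nM.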

Compound 3, half-maximal inhibitory concentration: 6.08 nM
Beside the measured number, compound 3's estimate is 3.0-fold (0.47 log units) above it; the range from low to high includes it.
By their numbers in this assay, from the lowest: compound 1; then compound 3; then compound 2.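

In this assay, going by these compounds alone, going from propyl to methyl on the amine nitrogen gives a 5.3-fold lower number from compound 2 to compound 3 (0.72 log units; beyond the scatter) and provides the first single-place step at this chain. With methyl held constant, the change in the group on the aromatic carbon gives a 2.1-fold higher number from compound 1 to compound 3 (0.32 log units; beyond the scatter) and shows that this second place also affects the read-out, though modestly. No measured evidence bears on the cause of either step. On these data alone, how an ethyl or a butyl chain on that nitrogen would read remains open, as does a free amine hydrogen there. As far as these compounds go, whether the two changes act independently also remains open.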